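Furan in place of benzofuran on two related nucleoside cores

The compounds below may be only part of what the source reports. "The series", "measured", "known", "first", "only" and "open" are said of these compounds alone.

Measured compounds:
- compound 1 `COc1ncnc2c1c(-c1cc3ccccc3o1)cn2[C@@H]1O[C@H](CO)[C@@H](O)[C@H]1O`: 4470 nM
- compound 2 `Nc1nc(N)c2c(-c3cc4ccccc4o3)cn([C@@H]3O[C@H](CO)[C@@H](O)[C@H]3O)c2n1`: > 15000 nM
- compound 3 `COc1ncnc2c1c(-c1ccco1)cn2[C@@H]1O[C@H](CO)[C@@H](O)[C@H]1O`: 100 nM

The three measured compounds were tested in a functional assay on HL-60 cells (Homo sapiens) for antiproliferative activity, read by XTT assay, with a stated time of 72 h; a higher number here means a weaker inhibitor, a lower number a stronger inhibitor. Compound 1 gives 4470 nM in this assay. Compound 3 gives 100 nM. For compound 2 the assay reports only a limit, > 15000 nM, and not a number.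

Compounds 1 and 3 share a core and differ in one place: furan-2-yl in place of 1-benzofuran-2-yl on an aromatic carbon. That change produced a 45-fold lower number from compound 1 to compound 3 (1.65 log units; beyond the scatter). Compound 2 carries a different core from compound 1; the difference between the two cores is not broken down here. Compound 2 and compound 4 `Nc1nc(N)c2c(-c3ccco3)cn([C@@H]3O[C@H](CO)[C@@H](O)[C@H]3O)c2n1` differ by the same kind of change as compounds 1 and 3: furan-2-yl in place of 1-benzofuran-2-yl on an aromatic carbon. The two places are described in the same words, so the change is made in the same surroundings on each core.

Compound 4 has not yet been measured in this assay. Its starting point is uncertain, since the value of compound 2 is only a limit, the one at the limit of > 15000 nM in this assay, at which 1 of the 3 values shown sits. Because the step of a 45-fold lower number from compound 1 to compound 3 (1.65 log units; beyond the scatter) was large, the same change on the core of compound 2 is expected to lower the number as well, and the step from compound 2 to compound 4 is estimated as an at least 10-fold lower number from compound 2 to compound 4 (1.00 log units; beyond the scatter). Compound 4 is accordingly expected to give about 1500 nM in this assay, with a likely range from 200 nM to 15000 nM. How far the weaker core of compound 2 carries over into compound 4 remains to be seen.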

Compound 4, half-maximal inhibitory concentration: > 20000 nM
Compound 4: a limit, no number (the forecaster's own chance of this, stated with the estimate: 25%); middle value at least 13-fold (1.12 log units) away from the limit.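

In this assay compound 4 gives > 20000 nM, a limit and not a number. Compound 2 also gives only a limit, > 15000 nM. The step between compound 2 and compound 4 therefore cannot be read. The compounds shown leave open whether furan-2-yl in place of 1-benzofuran-2-yl changes the number at all on the core of compound 2, as it does on the core of compound 1.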